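The source may report more compounds than this note shows. Statements on the series, on what has been measured and on what is new or still open speak of the compounds shown alone.

Measured compounds in a functional assay on VCaP cells (Homo sapiens) for antiproliferative activity, read by CCK-8 assay, with a stated time of 6 days; on this read-out lower numbers stand for stronger inhibition and higher numbers for weaker inhibition:
compound 1, `C[C@@H](Cn1ccc(-c2ccc(C#N)c(Cl)c2)n1)NC(=O)c1ccccc1F`, gives 2190 nM.
compound 2, `COC(=O)/C=C/C(=O)N[C@@H](C)Cn1ccc(-c2ccc(C#N)c(Cl)c2)n1`, gives 5230 nM.
compound 3, `C[C@@H](Cn1ccc(-c2ccc(C#N)c(Cl)c2)n1)Nc1ccccc1`, gives only the assay limit > 30000 nM.

Compound 3 thus stands at the limit (the limit of > 30000 nM in this assay, at which 1 of the 3 values shown sits), the only one of the three without a number; against it, an at least 13-fold higher number from compound 1 to compound 3 (1.13 log units; beyond the scatter) and an at least 5.7-fold higher number from compound 2 to compound 3 (0.75 log units; beyond the scatter) are both beyond the scatter. Compound 4, `C[C@@H](Cn1ccc(-c2ccc(C#N)c(Cl)c2)n1)Nc1ccncc1`, differs from compound 3 by pyridin-4-yl in place of phenyl on an amine nitrogen. Within the data shown here, none of the measured steps bears on this ring swap: a 2.4-fold higher number from compound 1 to compound 2 (0.38 log units; beyond the scatter), an at least 13-fold higher number from compound 1 to compound 3 (1.13 log units; beyond the scatter) and an at least 5.7-fold higher number from compound 2 to compound 3 (0.75 log units; beyond the scatter) all exchange the whole group on the amine nitrogen, carbonyl against aryl. A step of a number no higher from compound 3 to compound 4 (the limit leaves the size open) is therefore expected, none beyond the scatter, and compound 4 is estimated at 30000 nM (range 10000 nM to 100000 nM), most likely reported again only as a limit.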

Compound 4, half-maximal inhibitory concentration: 9900 nM
Compound 4: middle estimate off by 3.0-fold (0.48 log units), on the high side, and the stated range ends above it.
By their numbers in this assay, from the lowest: compound 1; then compounds 2 and 4 (each within the scatter of the next). At a limit, above all of these: compound 3.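

In this assay, the ring on the amine nitrogen matters by itself: an at least 3.0-fold lower number from compound 3 to compound 4 (0.48 log units; beyond the scatter) comes from pyridin-4-yl alone, with the carbonyl absent in both compounds. With pyridin-4-yl, loss of the carbonyl need not cost potency beyond the scatter, as a 1.9-fold higher number from compound 2 to compound 4 (0.28 log units; within the scatter) shows, although a 4.5-fold higher number from compound 1 to compound 4 (0.66 log units; beyond the scatter) remains against the fluorinated benzoyl amide. Compound 3 is a limit, so the first step fixes only a minimum size: the limit of > 30000 nM in this assay, at which 1 of the 4 values shown sits.

On these data alone, whether the ring nitrogen must sit as in pyridin-4-yl remains open, as pyridin-3-yl and pyridin-2-yl are absent here. Also open, as far as these compounds go, is whether the added hydrogen-bond acceptor accounts for the change.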